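This account rests on a few compounds, and the source may have more. Where it says the series, first, only, none or still open, it means among the compounds named here.

Measured so far:
- compound 1 `CN1C[C@H](C(=O)Nc2ccc(Br)cc2)[C@@H](c2ccc(/C=C/C(=O)Nc3ccccc3N)cc2)C1`: 3 mL/min/kg
- compound 2 `CC(C)(CO)N1C[C@H](C(=O)Nc2ccc(Cl)cc2)[C@@H](c2ccc(/C=C/C(=O)Nc3ccccc3N)cc2)C1`: 12 mL/min/kg

In an in vitro ADME assay on microsomes from liver (Homo sapiens) for pharmacokinetics, read by LC-MS, with a stated time of 10 min, tested at 1 uM (a lower number here means slower removal, a higher number faster removal of the compound), compound 2 gives 12 mL/min/kg, the higher of the two numbers. Compound 1 sits lower at 3 mL/min/kg, a gap beyond the scatter of repeated measurements. Within the data shown here, these two compounds differ in more than one place, so their values show only that gap, and no single-change step has been measured.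

Compound 3 `Nc1ccccc1NC(=O)/C=C/c1ccc([C@H]2CN(Cc3ccccc3)C[C@@H]2C(=O)Nc2ccc(Cl)cc2)cc1` keeps the rest of compound 2 and carries benzyl in place of 1-(hydroxymethyl)-1-methylethyl on an amine nitrogen in a ring. Among the measured compounds shown here, with no measured precedent for this change, the expectation is tentative. A small rise that stays within the scatter is expected, a 1.5-fold higher number from compound 2 to compound 3 (0.18 log units; within the scatter). For compound 3 the estimate is 18 mL/min/kg, with an expected range of 8 mL/min/kg to 40 mL/min/kg.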

Compound 3, clearance: 3 mL/min/kg
For compound 3 the middle estimate is 6.0-fold (0.78 log units) above the measured one, and the stated range ends above it.
By their numbers in this assay, from the lowest: compounds 1 and 3 (each within the scatter of the next); then compound 2.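

In this assay, this position on the amine nitrogen in the ring now has its first single-change reading: benzyl in place of 1-(hydroxymethyl)-1-methylethyl gives a 4.0-fold lower number from compound 2 to compound 3 (0.60 log units; beyond the scatter). With the (4-chlorophenyl)carbamoyl group and the rest of the core held constant, the choice of group at this nitrogen therefore shifts clearance beyond the scatter, and benzyl, despite its higher heavy-atom count and its aromatic ring, gives the lower number here. No measurement at hand accounts for the step.

This single step swaps the whole group, so it cannot separate losing the hydroxymethyl from gaining the aromatic ring. As far as these compounds go, a tert-butyl group or a pyridylmethyl group on the same nitrogen would help divide those two parts, and whether the step carries over to other anilide substituents also remains open.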